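The source may report more compounds than this note shows. Statements on the series, on what has been measured and on what is new or still open speak of the compounds shown alone.

Measured compounds:
- compound 1, `O=C(CN1CCCC1)Nc1ccc2ncnc(Nc3ccc(Cl)cc3)c2c1`: 16000 nM
- compound 2, `O=C(CN1CCCC1)Nc1ccc2ncnc(Nc3ccc(Cl)c(C(F)(F)F)c3)c2c1`: in a functional assay on MCF7 cells (Homo sapiens) for antiproliferative activity, read by MTT assay, with a stated time of 48 h (on this read-out higher numbers stand for weaker inhibition and lower numbers for stronger inhibition), compound 2 reaches only the limit > 100000 nM

Going by the values given here, compound 1 gives the only definite number in this assay; the other value shown is a limit. The step in this assay from compound 1 to compound 2 is an at least 6.2-fold higher number from compound 1 to compound 2 (0.79 log units; beyond the scatter), which rests on a limit of > 100000 nM in this assay, at which 1 of the 2 values shown sits, and so is known only as a lower bound of its size.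

Compound 3, `O=C(CN1CCCC1)Nc1ccc2ncnc(Nc3ccc(OCc4cccc(F)c4)cc3)c2c1`, is not yet measured. It differs from compound 1 in one place: (3-fluorobenzyl)oxy in place of chloro on an aromatic carbon.

Among the compounds with values here, only one measured step exists, and it concerns a trifluoromethyl added at a different site while the chloro stayed in place, so it speaks little to a change that removes the chloro itself. With no direct comparison to draw on, the expected step in this assay from compound 1 to compound 3 is a 1.3-fold lower number from compound 1 to compound 3 (0.12 log units; within the scatter), within the scatter, with a wide range. The estimate for compound 3 is 12000 nM, between 2000 nM and 60000 nM.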

Compound 3, half-maximal inhibitory concentration: 25000 nM
Compound 3: middle estimate off by 2.1-fold (0.32 log units), on the low side; the range from low to high includes it.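

Replacing chloro with (3-fluorobenzyl)oxy on this aromatic carbon gives a 1.6-fold higher number from compound 1 to compound 3 (0.19 log units; within the scatter), so this assay does not separate the two groups. This position therefore tolerates a much larger group, one that brings an extra aromatic ring and a hydrogen-bond acceptor, without a change beyond the scatter. The chloro is also not needed to keep this level of activity, which compound 2 could not show because it retains the chloro.

On these data alone, whether an amine, a carboxylic acid or a plain benzyloxy group without the fluorine would read the same on this carbon remains open. Nothing measured here explains why chloro and (3-fluorobenzyl)oxy read alike.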